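Working notes: replacing the 2,4-dimethoxyphenyl of compound 2

A few compounds are considered here, and "the series" means these few. Any claim that something is new, unique, unknown or untested is made for them only; others in the source may bear on it.

Values in a functional assay on NCI-H1299 cells (Homo sapiens) for antiproliferative activity, read by XTT assay, with a stated time of 72 h; on this read-out lower numbers stand for stronger inhibition and higher numbers for weaker inhibition:
- compound 1 `COc1ccc(-c2cc3ccccc3nc2C=O)cc1`: > 10000 nM, a limit of the assay
- compound 2 `COc1ccc(-c2cc3ccccc3nc2/C=C/C(=O)c2ccc(OC)cc2OC)cc1`: 3770 nM
- compound 3 `COc1ccc(-c2cc3ccccc3nc2/C=C/C(=O)c2ccc([N+](=O)[O-])cc2)cc1`: 770 nM

Compound 2, at 3770 nM, is the higher of the two true numbers, and compound 3 lies beyond the scatter from it. Compound 4 `COc1ccc(-c2cc3ccccc3nc2/C=C/C(=O)c2ccccn2)cc1` carries pyridin-2-yl in place of 2,4-dimethoxyphenyl on a carbonyl carbon. Among the compounds with values here, one measured step bears on this place: a 4.9-fold lower number from compound 2 to compound 3 (0.69 log units; beyond the scatter). The entering group there is different, so that step is a guide to scale only. A move in the same direction but of smaller size is expected in this assay, a 2.5-fold lower number from compound 2 to compound 4 (0.40 log units; beyond the scatter). For compound 4 the estimated value is 1500 nM, with an expected range of 400 nM to 6000 nM.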

Compound 4, half-maximal inhibitory concentration: 660 nM
The estimate for compound 4 lay 2.3-fold (0.36 log units) above the measured number; measured number inside the range.
By their numbers in this assay, from the lowest: compounds 4 and 3 (each within the scatter of the next); then compound 2. At a limit, above all of these: compound 1.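

In this assay, pyridin-2-yl on the carbonyl carbon gives a 5.7-fold lower number from compound 2 to compound 4 (0.76 log units; beyond the scatter), so a second, quite different group also lowers the number relative to 2,4-dimethoxyphenyl. The comparison with 4-nitrophenyl gives a 1.2-fold lower number from compound 3 to compound 4 (0.07 log units; within the scatter), so these two groups cannot be told apart at this place. Nothing at hand accounts for either step.

Open, as far as these compounds go, is whether a plain phenyl or a thiophene ring here would fall with compound 3 and compound 4 or with compound 2.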